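Replacing the pyridinyl arm with a methoxyphenyl group

The compounds below may be only part of what the source reports. "The series", "measured", "known", "first", "only" and "open" are said of these compounds alone.

In an assay on cells for inhibition of Ectonucleotide pyrophosphatase/phosphodiesterase family member 1 (Homo sapiens), with a stated time of 60 min (on this read-out lower numbers stand for stronger inhibition and higher numbers for weaker inhibition), compound 2 `COc1cc2nc(/C=C/c3cccnc3)nc(N3CCC(CCNS(N)(=O)=O)CC3)c2cc1OC` gives 58 nM, and compound 1 `COc1cc2nc(/C=C/c3ccccn3)nc(N3CCC(CCNS(N)(=O)=O)CC3)c2cc1OC` gives 71 nM, so the two lie within the scatter of each other, as the step of a 1.2-fold lower number from compound 1 to compound 2 (0.09 log units; within the scatter) shows. Compound 3 `COc1ccccc1/C=C/c1nc(N2CCC(CCNS(N)(=O)=O)CC2)c2cc(OC)c(OC)cc2n1` differs from compound 2 by 2-methoxyphenyl in place of pyridin-3-yl on a double-bonded chain carbon bound to a double-bonded chain carbon. Within the data shown here, the single measured step exchanged one pyridinyl isomer for another and left the number essentially unchanged; no measured step replaces a pyridinyl group with a methoxyphenyl group, so direct guidance is lacking. One would therefore expect no step beyond the scatter, a 1.1-fold higher number from compound 2 to compound 3 (0.05 log units; within the scatter). Compound 3 is estimated at 65 nM, between 20 nM and 220 nM.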

Compound 3, inhibition constant: 302 nM
Compound 3: the middle estimate sits 4.6-fold (0.67 log units) below what was measured, outside the stated range (above it).
By their numbers in this assay, from the lowest: compounds 2 and 1 (each within the scatter of the next); then compound 3.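

In this assay, the group on the double-bonded chain carbon proves not to be indifferent to exchange: the pyridinyl isomers had stayed within the scatter of each other, but 2-methoxyphenyl brings a 5.2-fold higher number from compound 2 to compound 3 (0.72 log units; beyond the scatter) and a 4.3-fold higher number from compound 1 to compound 3 (0.63 log units; beyond the scatter). Both steps are modest but beyond the scatter, and they point the same way. Nothing available explains this loss. On these data alone, whether the higher number goes with the methoxy group or with the ring of carbon only stays open; a plain phenyl group in this place would tell the two apart.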